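The source may report more compounds than this note shows. Statements on the series, on what has been measured and on what is new or still open speak of the compounds shown alone.

Compound 1 `COc1cc(C(=O)c2sc3ccccc3c2-c2ccc(C)cc2)cc(OC)c1OC`: 3500 nM
Compound 2 `COc1cc(C(=O)c2sc3ccccc3c2Nc2ccccc2)cc(OC)c1OC`: 2300 nM

In a functional assay on K562 cells (Homo sapiens) for antiproliferative activity, read by MTT assay, with a stated time of 72 h (on this read-out higher numbers stand for weaker inhibition and lower numbers for stronger inhibition), the numbers of compound 1 and compound 2 lie within the scatter of each other, so compound 2 has no clear lead. Compound 3 `COc1cc(C(=O)c2sc3ccccc3c2Nc2ccc(C)cc2)cc(OC)c1OC` differs from compound 2 by methyl in place of hydrogen on an aromatic carbon, with methyl in place of hydrogen on an aromatic carbon. Among the compounds with values here, the only measured step is a 1.5-fold lower number from compound 1 to compound 2 (0.18 log units; within the scatter), with anilino in place of 4-methylphenyl on an aromatic carbon. That step is a different change and stays within the scatter, so no step beyond the scatter is expected here. The expected step is a 1.2-fold lower number from compound 2 to compound 3 (0.06 log units; within the scatter). Compound 3 is estimated at 2000 nM, with an expected range of 600 nM to 6000 nM.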

Compound 3, half-maximal inhibitory concentration: 1600 nM
The estimate for compound 3 lay 1.3-fold (0.10 log units) above the measured number; measured number inside the range.
By their numbers in this assay, from the lowest: compounds 3, 2 and 1 (each within the scatter of the next, the first and the last beyond it).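

In this assay, the change from anilino to (4-methylphenyl)amino gives a 1.4-fold lower number from compound 2 to compound 3 (0.16 log units; within the scatter) and so shows that this place on the ring can carry a methyl, though the gain cannot be told from scatter. Within the data shown here, with the 4-methylphenyl group present in both compounds, adding the amino link gives a 2.2-fold lower number from compound 1 to compound 3 (0.34 log units; beyond the scatter) and is the first step here to pass the scatter, if only modestly. Nothing measured here explains either step. The compounds shown leave open what a methoxy, chloro or carboxylic acid group at this same place would do to the number.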